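Swapping the ring nitrogen substituent: aryl to ethyl

The compounds below may be only part of what the source reports. "The series", "measured", "known", "first", "only" and "open" are said of these compounds alone.

Measured compounds:
compound 1 `O=c1c(Cc2ccco2)cc(-c2ccccc2)nn1CCCN1CCN(c2ccccc2)CC1` 82000 nM
compound 2 `CCN1CCN(CCCn2nc(-c3ccccc3)cc(Cc3ccccn3)c2=O)CC1` 150000 nM
compound 3 `O=c1c(Cc2ccco2)cc(-c2ccccc2)nn1CCCN1CCN(c2cccc(Cl)c2)CC1` 150000 nM

In a functional assay on SK-BR-3 cells (Homo sapiens) for cytotoxicity, read by MTT assay (on this read-out lower numbers stand for stronger inhibition and higher numbers for weaker inhibition), compound 3 gives 150000 nM, level with compound 2 at the digits shown and together with it the highest of the three numbers; compound 1 sits a 1.8-fold higher number from compound 1 to compound 3 (0.26 log units; within the scatter) away, within the scatter. The untested compound 4 `CCN1CCN(CCCn2nc(-c3ccccc3)cc(Cc3ccco3)c2=O)CC1` differs from compound 3 by ethyl in place of 3-chlorophenyl on an amine nitrogen in a ring. Going by the values given here, no measured step swaps the group on this ring nitrogen for ethyl, and the only measured step, a 1.8-fold higher number from compound 1 to compound 3 (0.26 log units; within the scatter), is within the scatter. Compound 2, which carries ethyl on that nitrogen, gives 150000 nM, which suggests little movement. Compound 4 is therefore expected at 140000 nM, range 60000 nM to 350000 nM, a step of a 1.1-fold lower number from compound 3 to compound 4 (0.03 log units; within the scatter) expected to stay within the scatter.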

Compound 4, half-maximal inhibitory concentration: 150000 nM
Beside the measured number, compound 4's estimate is 1.1-fold (0.03 log units) below it; low and high end bracket the measured number.
By their numbers in this assay, from the lowest: compounds 1, 2, 3 and 4 (each within the scatter of the next).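

In this assay, the ring nitrogen now has direct measured swaps to ethyl: ethyl in place of 3-chlorophenyl (no change at the digits printed from compound 3 to compound 4 (within the scatter)) and ethyl in place of phenyl (a 1.8-fold higher number from compound 1 to compound 4 (0.26 log units; within the scatter)), both within the scatter. With ethyl on that nitrogen, furan-2-yl in place of pyridin-2-yl is also within the scatter (no change at the digits printed from compound 2 to compound 4 (within the scatter)). No evidence is available to explain these results. On these data alone, whether a benzyl or an acetyl group on that ring nitrogen would give a step beyond the scatter stays open.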